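Sulfonamide-diamine series: arylsulfonyl swap from compound 1

The source may hold more compounds than are shown below. What is called first, only, known or untested is meant among the compounds shown, and "the series" means these compounds.

Measured so far in a functional assay on MIA PaCa-2 cells (Homo sapiens) for inhibition, read by MTT assay, with a stated time of 72 h; a lower number here means a stronger inhibitor of growth, a higher number a weaker inhibitor of growth:
compound 1, `O=S(=O)(NCCCCCCNCc1ccc(Br)cc1)c1cc(Cl)cc(Cl)c1`: 12000 nM
compound 2, `O=S(=O)(NCCCNCc1ccc(-c2ccccc2)cc1)c1cc(C(F)(F)F)cc(C(F)(F)F)c1`: 2400 nM
compound 3, `CC(C)(C)c1ccc(CNCCNS(=O)(=O)c2cc(C(F)(F)F)cc(C(F)(F)F)c2)cc1`: 15000 nM

Among these three numbers compound 1 stands second highest. Compound 3 sits within the scatter of compound 1, so no order between them is claimed; compound 2 lies furthest from compound 1, with the lower number, and that gap is beyond the scatter. No pair of measured compounds differs in one place only, so nothing shown isolates the part on the sulfonyl sulfur.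

Compound 4, `Cc1ccc(S(=O)(=O)NCCCCCCNCc2ccc(Br)cc2)cc1`, differs from compound 1 by 4-methylphenyl in place of 3,5-dichlorophenyl on a sulfonyl sulfur. For the measured compounds named here, with no measured step of this kind, the change is expected to be modest, most likely towards a higher number, and it may not reach beyond the scatter. Compound 4 is estimated at 20000 nM, with a range of 8000 nM to 50000 nM. This corresponds to an expected step of a 1.7-fold higher number from compound 1 to compound 4 (0.22 log units; within the scatter).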

Compound 4, concentration for 50% growth inhibition: 12300 nM
Beside the measured number, compound 4's estimate is 1.6-fold (0.21 log units) above it; the measured number falls inside the stated range.
By their numbers in this assay, from the lowest: compound 2; then compounds 1, 4 and 3 (each within the scatter of the next).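

For the compounds shown here, this is the first comparison that isolates the part on the sulfonyl sulfur. In this assay the change to 4-methylphenyl in place of 3,5-dichlorophenyl reads a 1.0-fold higher number from compound 1 to compound 4 (0.01 log units; within the scatter) and so does not separate these two groups on the shared core. No measured property bears on this result.

Going by these compounds, a phenyl ring carrying an amine or a carboxylic acid on the sulfonyl sulfur remains open, as does a simple alkyl chain there. On these data alone, whether the same swap reads alike on the diamine chains of compound 2 and compound 3 also stays open.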